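This account rests on a few compounds, and the source may have more. Where it says the series, first, only, none or still open, it means among the compounds named here.

Compound 1 `CN1C(=O)C(C2CC2)N(C)c2nc(Nc3ccc(S(N)(=O)=O)cc3)ncc21` and compound 2 `CN1C(=O)C(c2cccc(F)c2)N(C)c2nc(Nc3ccc(S(N)(=O)=O)cc3)ncc21` share one core and differ only in the group on a saturated ring carbon. In an assay on Sf9 cells for inhibition of serine/threonine-protein kinase 4 (Homo sapiens), read by luminescence and ADP-Glo, with a stated time of 1 h, in the presence of a further agent that is not named here (a higher number here means a weaker inhibitor, a lower number a stronger inhibitor), compound 1 gives 136 nM and compound 2 gives 134 nM. Compound 2 holds the lowest of the two numbers, but the step of a 1.0-fold lower number from compound 1 to compound 2 (0.01 log units; within the scatter), 3-fluorophenyl in place of cyclopropyl, lies within the scatter, so the two compounds cannot be ordered. Compound 3 `Cc1ccc(F)cc1C1C(=O)N(C)c2cnc(Nc3ccc(S(N)(=O)=O)cc3)nc2N1C` differs from compound 2 by methyl in place of hydrogen on an aromatic carbon; cut one bond further out, the change reads 3-fluorophenyl to 5-fluoro-2-methylphenyl. Within the data shown here, no measured step touches this aromatic ring itself. Among the measured compounds shown here, the only step known, a 1.0-fold lower number from compound 1 to compound 2 (0.01 log units; within the scatter), exchanged the whole group on that saturated carbon and barely moved the number, which suggests that changes at this group may matter little. Compound 3 is therefore expected to give about 150 nM, with a range from 60 nM to 400 nM. The expected step of a 1.1-fold higher number from compound 2 to compound 3 (0.05 log units; within the scatter) would lie within the scatter.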

Compound 3, half-maximal inhibitory concentration: 168 nM
Estimate against measurement, compound 3: 1.1-fold (0.05 log units) below, and the stated range covers the measured number.
By their numbers in this assay, from the lowest: compounds 2, 1 and 3 (each within the scatter of the next).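

In this assay, among these compounds, methyl in place of hydrogen, on an aromatic carbon ortho to a large group and para to a fluoro group, gives a 1.3-fold higher number from compound 2 to compound 3 (0.10 log units; within the scatter); this is the first measured change on the aromatic ring itself, and it stays within the scatter. Putting 5-fluoro-2-methylphenyl in place of cyclopropyl on the saturated ring carbon gives a 1.2-fold higher number from compound 1 to compound 3 (0.09 log units; within the scatter), so the three groups at this carbon cannot be told apart by their numbers. Nothing available explains why these numbers stay so close.

With every step shown lying within the scatter, it remains open whether any group at this aromatic carbon can shift the number measurably. An amine, a carboxylic acid or a longer chain in place of the methyl would test that.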